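The source may hold more compounds than are shown below. What is called first, only, known or untested is meant among the compounds shown, and "the series" means these compounds.

Of the compounds shown here, three of one shared core have been measured in a functional assay on HeLa cells (Homo sapiens) for inhibition, read by MTT assay, with a stated time of 72 h; a lower number here means a stronger inhibitor, a higher number a weaker inhibitor. Compound 1 `CN(C(=O)NC(=O)c1c(F)cccc1F)c1nc(C(F)(F)F)c(C(=O)N/N=C/c2cccc(C(F)(F)F)c2)s1` gives 21.6 ug/mL. Compound 2 `CN(C(=O)NC(=O)c1ccc([N+](=O)[O-])cc1)c1nc(C(F)(F)F)c(C(=O)N/N=C/c2ccc([N+](=O)[O-])cc2)s1` gives 8.42 ug/mL, the middle number of the three, with compound 3 nearest and compound 1 furthest. Compound 3 `CN(C(=O)NC(=O)c1ccc(Cl)c(Cl)c1)c1nc(C(F)(F)F)c(C(=O)N/N=C/c2ccc([N+](=O)[O-])cc2)s1` gives 5.12 ug/mL.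

The step of interest leads from compound 2 to compound 4 `CN(C(=O)NC(=O)c1ccc([N+](=O)[O-])cc1)c1nc(C(F)(F)F)c(C(=O)N/N=C/c2cccc(C(F)(F)F)c2)s1`. The change is 3-(trifluoromethyl)phenyl in place of 4-nitrophenyl on a carbon with a double bond to nitrogen. Among the compounds with values here, the only measured step within one change, from compound 2 to compound 3, is a 1.6-fold lower number from compound 2 to compound 3 (0.22 log units; within the scatter), but it alters the group on the carbonyl carbon, not the group on the carbon doubly bonded to nitrogen, so it does not speak to this change. Compound 1 carries the incoming group, yet it differs from compound 2 in two places, so its higher number cannot be attributed to either change alone. Within the data shown here, no directly comparable step exists, and the expectation therefore rests on what compounds 1 and 2 show together. For compound 4 the estimated result is 13 ug/mL, within 6 ug/mL to 28 ug/mL, which means an expected step of a 1.5-fold higher number from compound 2 to compound 4 (0.19 log units; within the scatter), leaning toward a weaker inhibitor but possibly within the scatter.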

Compound 4, half-maximal inhibitory concentration: 4.12 ug/mL
Estimate against measurement, compound 4: 3.2-fold (0.50 log units) above; measured number below the stated range.
By their numbers in this assay, from the lowest: compounds 4, 3 and 2 (each within the scatter of the next, the first and the last beyond it); then compound 1.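

Read directly in this assay, exchanging the group on a carbon with a double bond to nitrogen gives a 2.0-fold lower number from compound 2 to compound 4 (0.31 log units; beyond the scatter), so this position can change the number on its own, and this swap moves it toward a stronger inhibitor. With 3-(trifluoromethyl)phenyl held fixed, 4-nitrophenyl in place of 2,6-difluorophenyl on a carbonyl carbon gives a 5.2-fold lower number from compound 1 to compound 4 (0.72 log units; beyond the scatter), which ties the high number of compound 1 to its group on the carbonyl carbon, not to the group it shares with compound 4. Nothing available explains either step.

Within the data shown here, only two groups are compared at this position, so a plain phenyl, a 4-aminophenyl or a 4-carboxyphenyl there remains an open case. Also open, from the compounds shown here alone, is whether 3,4-dichlorophenyl on the carbonyl carbon would combine with 3-(trifluoromethyl)phenyl to give a still lower number.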